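This account rests on a few compounds, and the source may have more. Where it says the series, first, only, none or still open, it means among the compounds named here.

Measured in an ADME assay on MT4 cells (Homo sapiens) for cytotoxicity; a higher number here means that more compound is tolerated, a lower number that less compound is tolerated:
Compound 1 `FC(F)(F)c1cccc(NC(=S)Nc2ccc(Cl)cc2)c1`: 6800 nM
Compound 2 `FC(F)(F)c1cccc(NC(=S)Nc2ccccc2)c1`: 39000 nM

Compound 2 stands highest of these two. Compound 3 `CCNC(=S)Nc1cccc(C(F)(F)F)c1` departs from it by ethyl in place of phenyl on an amide-type nitrogen. Going by the values given here, only one measured step offers guidance, and only indirectly, since it involves a different change: a 5.7-fold higher number from compound 1 to compound 2 (0.76 log units; beyond the scatter), with hydrogen in place of chloro on an aromatic carbon. Among the compounds with values here, a modest upward step of similar size is therefore expected in this assay, though no measured step tests this change directly. The expected step is a 2.3-fold higher number from compound 2 to compound 3 (0.36 log units; beyond the scatter). The estimate for compound 3 is 90000 nM, with an expected range of 30000 nM to 250000 nM.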

Compound 3, half-maximal cytotoxic concentration: > 100000 nM
Compound 3: a limit, no number (the forecaster's own chance of this, stated with the estimate: 35%); at least 1.1-fold (0.04 log units) between middle value and limit.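

In this assay compound 3 gives > 100000 nM, which is a limit and not a number. Ethyl in place of phenyl on the amide-type nitrogen brings an at least 2.5-fold higher number from compound 2 to compound 3 (0.40 log units; beyond the scatter), and ethyl in place of 4-chlorophenyl brings an at least 14-fold higher number from compound 1 to compound 3 (1.16 log units; beyond the scatter). Compounds 1 and 2 differed only by chloro on an aromatic carbon, whereas these steps show that replacing the whole aromatic ring at this position also raises the number, by an amount the limit leaves unfixed.

Still open, as far as these compounds go, is whether the aromatic ring itself matters, since a cyclohexyl group or a longer chain such as butyl on the same nitrogen would test this.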